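The source may hold more compounds than are shown below. What is called first, only, known or untested is meant among the compounds shown, and "the series" means these compounds.

Working notes on the series. The measurements come from a functional assay on MGC-803 cells (Homo sapiens) for inhibition, read by MTT assay, with a stated time of 48 h; a lower number here means a stronger inhibitor, a higher number a weaker inhibitor. Three compounds carry numbers. Compound 1 `C/C=C/C(=O)N(Cc1cccc(O)c1)c1cc(OC)c(OC)c(OC)c1` gives 14100 nM in this assay. Compound 2 `COc1ccc(CN(C(=O)CCl)c2cc(OC)c(OC)c(OC)c2)cc1O` gives 84 nM in this assay. Compound 3 `COc1ccc(N(Cc2cc(OC)c(OC)c(OC)c2)C(=O)CCl)cc1O` gives 24500 nM in this assay. Compound 2 stands lowest of the three; its nearest neighbour on the numbers is compound 1, and the distance to it is beyond the scatter, as is the larger distance to compound 3. Among the measured compounds shown here, no single-point step between measured compounds is available, so none of these gaps can be tied to one structural change.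

Compound 4 `COc1ccc(CN(C(=O)/C=C/CBr)c2cc(OC)c(OC)c(OC)c2)cc1O` has not been measured in this assay. It differs from compound 2 in one place: 3-bromoprop-1-en-1-yl in place of chloromethyl on a carbonyl carbon. Nothing measured in the series shows what this exchange does on the carbonyl carbon of the amide-type nitrogen, so the expectation rests on compound 2 alone, whose 84 nM sets the starting point. The step from compound 2 to compound 4 is expected to be a 3.0-fold higher number from compound 2 to compound 4 (0.47 log units; beyond the scatter), a modest move towards a higher number, with wide uncertainty in both directions. For compound 4 in this assay the estimate is 250 nM, within a range from 40 nM to 2000 nM.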

Compound 4, half-maximal inhibitory concentration: 71 nM
For compound 4 the middle estimate is 3.5-fold (0.55 log units) above the measured one, and the stated range covers the measured number.
By their numbers in this assay, from the lowest: compounds 4 and 2 (each within the scatter of the next); then compounds 1 and 3 (each within the scatter of the next).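

In this assay, the carbonyl carbon of the amide-type nitrogen now has its first comparison in one place: a 1.2-fold lower number from compound 2 to compound 4 (0.07 log units; within the scatter), so compound 2 and compound 4 cannot be told apart. On this core, the position takes 3-bromoprop-1-en-1-yl as well as chloromethyl with no difference beyond the scatter, although the exchange alters the chain, adds a double bond outside aromatic rings and puts bromine in place of chlorine. This single step cannot separate those three features, and no independent measurement bears on the result.

The compounds shown leave open how the chain and the halogen each contribute, since neither 3-chloroprop-1-en-1-yl nor bromomethyl on this carbonyl carbon appears among them to separate the two. Whether a halogen is needed at this position at all also remains unanswered, as the compounds shown include no comparison on this core with a halogen-free group there, such as a plain ethyl chain or an amine.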